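Swapping a Pyridazine Amide for a Thiazole Amide

A few compounds are considered here, and "the series" means these few. Any claim that something is new, unique, unknown or untested is made for them only; others in the source may bear on it.

Compound 1, `CNc1ncnc2c(CNc3cc(NC(=O)c4cc(C(F)(F)F)cc(C(F)(F)F)c4)ccc3C)cccc12`, gives 769 nM in a functional assay on A375P cells (Homo sapiens) for cytotoxicity, read by MTT assay, with a stated time of 24 h; a higher number here means a weaker inhibitor, a lower number a stronger inhibitor.
Compound 2, `CNc1ncnc2c(CNc3cc(NC(=O)c4ccnnc4)ccc3C)cccc12`, gives 61700 nM in this assay.

Going by the values given here, only two compounds have been measured so far, and compound 2 stands at the higher of the two numbers, that is, it is the weaker inhibitor. The gap to compound 1 is well beyond the usual scatter, so on what is known, compound 2 is clearly the less active of the pair.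

Compound 3, `CNc1ncnc2c(CNc3cc(NC(=O)c4cscn4)ccc3C)cccc12`, has not yet been measured. It differs from compound 2 in one place: 1,3-thiazol-4-yl in place of pyridazin-4-yl on a carbonyl carbon. Nothing measured here tells how such a swap of one small aromatic ring for another behaves on this carbonyl carbon, so the expectation rests on compound 2 alone. Compound 3 is expected to remain a weak inhibitor, with a step of a 2.1-fold lower number from compound 2 to compound 3 (0.31 log units; beyond the scatter) that may be a modest lowering but could equally be none beyond the scatter. The estimate for compound 3 in this assay is 30000 nM, within a range from 8000 nM to 100000 nM.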

Compound 3, half-maximal inhibitory concentration: 1900 nM
Compound 3: middle estimate off by 16-fold (1.20 log units), on the high side, and the stated range ends above it.
By their numbers in this assay, from the lowest: compound 1; then compound 3; then compound 2.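

The change from pyridazin-4-yl to 1,3-thiazol-4-yl on the carbonyl carbon gives a 32-fold lower number from compound 2 to compound 3 (1.51 log units; beyond the scatter) in this assay, so this position is highly sensitive even to a swap of one small aromatic ring for another, although both rings count the same hydrogen-bond donors and acceptors and neither carries a net charge. Going by these compounds alone, the trifluoromethyl-bearing ring is also not the only group here that gives a number far below that of compound 2: compound 1 gives 769 nM and compound 3 gives 1900 nM, with compound 3 still the higher of these two. Nothing measured here accounts for the size of this step, which for now remains an observation without an explanation.

Still open, going by these compounds, is whether the lower number belongs to the 1,3-thiazol-4-yl ring in particular or would also come with other rings on this carbonyl carbon, such as a plain phenyl, a thiophene or a pyridine. It is equally open whether the order of these compounds would hold in other cell lines or at other exposure times.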